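Working notes: from compound 3 to compound 4

The source may hold more compounds than are shown below. What is called first, only, known or untested is meant among the compounds shown, and "the series" means these compounds.

Measured in a functional assay on MCF7 cells (Homo sapiens) for inhibition, read by MTT assay, with a stated time of 4 days (on this read-out lower numbers stand for stronger inhibition and higher numbers for weaker inhibition), so far:
- compound 1 `COc1cc(NC(C)CCCNC(=O)NNC(=O)NCCCCCO)c2ncccc2c1` gives 4000 nM
- compound 2 `COc1cc(NC(C)CCCNC(=O)NNC(=O)Nc2ccc(Cl)c(C(F)(F)F)c2)c2ncccc2c1` gives 2000 nM
- compound 3 `COc1cc(NC(C)CCCNC(=O)NNC(=O)NCCO)c2ncccc2c1` gives 13000 nM

Compound 3 has the highest number of the three, and its steps to both others lie beyond the scatter. The next compound is compound 4 `COc1cc(NC(C)CCCNC(=O)NNC(=O)NC(CO)(CO)CO)c2ncccc2c1`, not yet measured. The change 2-hydroxy-1,1-bis(hydroxymethyl)ethyl in place of 2-hydroxyethyl on an amide-type nitrogen puts 2-hydroxy-1,1-bis(hydroxymethyl)ethyl in place of 2-hydroxyethyl on an amide-type nitrogen.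

For the measured compounds named here, two measured steps bear on this change. The closer one is a 3.3-fold higher number from compound 1 to compound 3 (0.51 log units; beyond the scatter), which links the two compounds with hydroxy-bearing chains. The other is a 6.5-fold higher number from compound 2 to compound 3 (0.81 log units; beyond the scatter), and both are modest. Going by the values given here, no measured compound carries a branched group here, so the guidance is weak. A higher number is the likelier direction, but the expected step is small: a 1.4-fold higher number from compound 3 to compound 4 (0.14 log units; within the scatter) is estimated, which does not clearly pass the scatter. For compound 4 the estimated value in this assay is 18000 nM, with an expected range from 6000 nM to 50000 nM.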

Compound 4, half-maximal inhibitory concentration: 28000 nM
For compound 4 the middle estimate is 1.6-fold (0.19 log units) below the measured one, and the stated range covers the measured number.
By their numbers in this assay, from the lowest: compounds 2 and 1 (each within the scatter of the next); then compound 3; then compound 4.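

In this assay the branched 2-hydroxy-1,1-bis(hydroxymethyl)ethyl group on the amide-type nitrogen gives a 2.2-fold higher number from compound 3 to compound 4 (0.33 log units; beyond the scatter) and so moves the number further up, beyond the scatter, from the value of the 2-hydroxyethyl compound. Replacing the other two groups with the same branched group gives a 7.0-fold higher number from compound 1 to compound 4 (0.85 log units; beyond the scatter) and a 14-fold higher number from compound 2 to compound 4 (1.15 log units; beyond the scatter), the second being the only large step shown and leaving the branched compound with the highest number of the four. No evidence on hand gives a cause for these steps.

Branching and the added hydroxymethyl groups enter together in this change, so their separate contributions stay open. From the compounds shown here alone, a tert-butyl group would separate them, and how an amine or a carboxylic acid at the end of the chain would compare also remains open.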